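The source may report more compounds than this note shows. Statements on the series, on what has been measured and on what is new or still open speak of the compounds shown alone.

Measured compounds in a functional assay on MDA-MB-231 cells (Homo sapiens) for cytotoxicity, read by MTT assay, with a stated time of 48 h; on this read-out lower numbers stand for stronger inhibition and higher numbers for weaker inhibition:
- compound 1, `O=C(/C=C/c1ccc2c(c1)B(O)OC2)c1ccc(-c2ccccc2)cc1`, 6400 nM
- compound 2, `O=C(/C=C/c1ccc2c(c1)B(O)OC2)c1cccs1`, 4600 nM
- compound 3, `O=C(/C=C/c1ccc2c(c1)B(O)OC2)c1cccnc1`, 11400 nM

All three compounds share the same core and differ only in the group on the carbonyl carbon. Compound 3 gives the highest number of the three in this assay: compound 1 lies within the scatter of it, while compound 2 lies beyond it. Among the compounds with values here, the one single-point step among the measured compounds is the swap from thiophen-2-yl to pyridin-3-yl, which gave a 2.5-fold higher number from compound 2 to compound 3 (0.39 log units; beyond the scatter).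

Compound 4, `O=C(/C=C/c1ccc2c(c1)B(O)OC2)c1ccc(Br)cc1`, has not yet been measured. It differs from compound 3 by 4-bromophenyl in place of pyridin-3-yl on a carbonyl carbon. Within the data shown here, no measured step changes a six-membered aromatic ring with one hetero atom for a six-membered aromatic ring of carbon only at this position, so the nearest guide is the step from compound 2 to compound 3, which moved the number by a modest amount, and the number for compound 1, which also carries a six-membered aromatic ring of carbon only on the carbonyl carbon and sits within the scatter of compound 3.

On that basis compound 4 is expected to give a modestly lower number, a 1.8-fold lower number from compound 3 to compound 4 (0.24 log units; within the scatter), with the estimate for compound 4 being 6500 nM within a range from 2500 nM to 15000 nM.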

Compound 4, half-maximal inhibitory concentration: 9500 nM
Compound 4: the middle estimate sits 1.5-fold (0.16 log units) below what was measured; low and high end bracket the measured number.
By their numbers in this assay, from the lowest: compounds 2, 1, 4 and 3 (each within the scatter of the next, the first and the last beyond it).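

In this assay, within the data shown here, 4-bromophenyl in place of pyridin-3-yl on the carbonyl carbon gave a 1.2-fold lower number from compound 3 to compound 4 (0.08 log units; within the scatter), the first measured exchange here of a six-membered aromatic ring with one hetero atom for one of carbon only, and bromo in place of phenyl on an aromatic carbon gave a 1.5-fold higher number from compound 1 to compound 4 (0.17 log units; within the scatter), so neither change moved the number beyond the scatter. Thiophen-2-yl now stands apart from two of the other groups on the carbonyl carbon, since 4-bromophenyl in its place gave a 2.1-fold higher number from compound 2 to compound 4 (0.31 log units; beyond the scatter) in addition to the earlier step to compound 3, although compound 1 remains within the scatter of compound 2 and so goes against any clean split between the thiophene and the six-membered rings. No measurement shown here offers an explanation for these numbers.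

The compounds shown leave open what an unsubstituted phenyl on the carbonyl carbon would give, so the part played by the bromo alone remains unknown. They also leave open whether an amine or a carboxylic acid in place of the bromo would move the number beyond the scatter of compound 4.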